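The source may hold more compounds than are shown below. What is called first, only, known or untested is meant among the compounds shown, and "the series" means these compounds.

Measured in a physicochemical assay for solubility, read by HPLC, in phosphate buffer, measured as kinetic solubility, at pH 7.4; on this read-out higher numbers stand for higher solubility and lower numbers for lower solubility:
compound 1 `CCOC(=O)c1cc(-c2ccc(OC)cc2)n(-c2ccc(S(N)(=O)=O)cc2)c1C`: 16100 nM
compound 2 `CCC(=O)c1cc(-c2ccc(S(N)(=O)=O)cc2)nn1-c1ccc(Cl)cc1`: 49600 nM
compound 3 `CCC(=O)c1cc(-c2ccc(S(N)(=O)=O)cc2)nn1-c1cccc(Cl)c1`: 700 nM

Compound 2 holds the highest of these three numbers, clear of compound 1 and much further from compound 3. The next compound to be measured, compound 4 `CCCC(=O)c1cc(-c2ccc(S(N)(=O)=O)cc2)nn1-c1ccc(Cl)cc1`, keeps compound 2 intact except for one change: methyl in place of hydrogen on a saturated chain carbon, two bonds along the chain from a carbonyl carbon. Cut one bond further out, the same change reads propanoyl to propylcarbonyl.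

Among the measured compounds shown here, no measured step covers this change. For the measured compounds named here, the only step between two compounds that differ in one place is a 71-fold lower number from compound 2 to compound 3 (1.85 log units; beyond the scatter), a large move beyond the scatter. It lies elsewhere in the structure, with 3-chlorophenyl in place of 4-chlorophenyl on an aromatic nitrogen. It shows that one change can move the number far in this small set, but it gives no direct guide to the chain. Compound 2, at 49600 nM, stands at the top of the numbers seen so far, so a moderate move to a lower number in this assay is expected, and a step within the scatter remains possible. The estimated step is a 2.5-fold lower number from compound 2 to compound 4 (0.39 log units; beyond the scatter). For compound 4 the expected value is 20000 nM, with an estimated range from 4000 nM to 70000 nM.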

Compound 4, solubility: 400 nM
Beside the measured number, compound 4's estimate is 50-fold (1.70 log units) above it; measured number below the stated range.
By their numbers in this assay, from the lowest: compounds 4 and 3 (each within the scatter of the next); then compound 1; then compound 2.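

In this assay, the propanoyl chain of compound 2 proves to be a highly sensitive site: methyl in place of hydrogen on a saturated chain carbon, two bonds along the chain from a carbonyl carbon, gives a 120-fold lower number from compound 2 to compound 4 (2.09 log units; beyond the scatter). Among the compounds shown here, the only earlier step, a 71-fold lower number from compound 2 to compound 3 (1.85 log units; beyond the scatter), concerned the chlorophenyl group on an aromatic nitrogen and said nothing about the chain, so these compounds now show large steps from compound 2 at two separate places in its structure. No accompanying measurement bears on why the number falls this far with this change.

The compounds shown leave open whether the steep fall belongs to this one propanoyl to propylcarbonyl change or continues along a series, since neither a shorter acetyl chain nor a longer butyl or pentyl chain appears among them. They also leave open how a branched chain, an amine or a carboxylic acid on the chain would read, and whether the same methyl change would give a step of similar size on compound 3.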